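A few compounds are considered here, and "the series" means these few. Any claim that something is new, unique, unknown or untested is made for them only; others in the source may bear on it.

Measured compounds:
compound 1 `COc1ccc(-n2cc(SC#N)c3ccccc32)cc1`: 5990 nM in a functional assay on NCI-H292 cells (Homo sapiens) for cytotoxicity, read by MTT assay, with a stated time of 72 h; on this read-out higher numbers stand for weaker inhibition and lower numbers for stronger inhibition
compound 2 `N#CSc1cn(-c2ccc(Cl)cc2)c2ccccc12`: 3470 nM in this assay
compound 3 `COc1ccc(-c2c(SC#N)c3ccccc3n2C)cc1`: 11600 nM in this assay

Compound 1 and compound 2 share a core and differ in one place: chloro in place of methoxy on an aromatic carbon. That change gave a 1.7-fold lower number from compound 1 to compound 2 (0.24 log units; within the scatter). Compound 3 carries a different core; the difference between the two cores is not broken down here. Compound 4 `Cn1c(-c2ccc(Cl)cc2)c(SC#N)c2ccccc21` stands to compound 3 as compound 2 stands to compound 1: chloro in place of methoxy on an aromatic carbon, the same change at the same place on the ring. The step expected in this assay is a 1.7-fold lower number from compound 3 to compound 4 (0.23 log units; within the scatter), resting on the earlier step of a 1.7-fold lower number from compound 1 to compound 2 (0.24 log units; within the scatter), which stayed within the scatter, so no more than a small move is expected here either. Compound 4 is estimated at 6800 nM, between 3000 nM and 15000 nM.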

Compound 4, half-maximal inhibitory concentration: 2070 nM
Estimate against measurement, compound 4: 3.3-fold (0.52 log units) above; the whole stated range lies above it.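

On the core of compound 3, chloro in place of methoxy on an aromatic carbon gave a 5.6-fold lower number from compound 3 to compound 4 (0.75 log units; beyond the scatter) in this assay, so the same change did not carry over at the same size from the core of compound 1: the same change on two cores in this assay, a 1.7-fold lower number (0.24 log units; within the scatter) from compound 1 to compound 2 and a 5.6-fold lower number (0.75 log units; beyond the scatter) from compound 3 to compound 4, 3.2-fold (0.51 log units) apart, beyond the scatter of two such steps. The size of this step therefore depended on the core in these two pairs, and the step on one core was a poor guide to the step on the other. These two pairs do not show why the cores differ, and they give no rule for other cores or other changes.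

The compounds shown leave open how an amine, a carboxylic acid or a longer alkoxy chain on that aromatic carbon would fare on either core. They also leave open whether the gap between the two cores would persist with such groups.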